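Replacing sec-butyl with allyl on the amine nitrogen

The source may hold more compounds than are shown below. What is called first, only, known or untested is meant among the compounds shown, and "the series" means these compounds.

Three compounds share one core and differ only in the group on the amine nitrogen. Compound 1 `COc1cc(/C=C/C(=O)/C=C(/C=C/c2ccc(OC(C)=O)c(OC)c2)NC2CCCCC2)ccc1OC(C)=O` gives 0.01% in a functional assay for inhibition, read by spectrophotometry, with a stated time of 30 min, tested at 1 uM; on this read-out lower numbers stand for less inhibition and higher numbers for more inhibition at the one concentration tested (going by the name of the read-out). Compound 2 `CCCNC(=C\C(=O)/C=C/c1ccc(O)c(OC)c1)/C=C/c1ccc(O)c(OC)c1` gives 0.1% in the same assay. Going by the values given here, compound 3 `CCC(C)NC(=C\C(=O)/C=C/c1ccc(O)c(OC)c1)/C=C/c1ccc(O)c(OC)c1` gives 0.13%, a number that lies within the usual scatter of both other values, so no compound can be set apart from the others here.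

Compound 4 `C=CCNC(=C\C(=O)/C=C/c1ccc(O)c(OC)c1)/C=C/c1ccc(O)c(OC)c1` carries allyl in place of sec-butyl on an amine nitrogen. Among the compounds with values here, the only measured step, a number 0 percentage points higher from compound 2 to compound 3 (within the scatter), concerns a different change and shows nothing beyond the scatter. Within the data shown here, no measured step involves the allyl group itself, so the expectation rests on the fact that every change seen so far has left the read-out essentially unchanged.

For compound 4 the step of a number 0 percentage points lower from compound 3 to compound 4 (within the scatter) is expected to stay within the scatter. Compound 4 is estimated to give 0.1%, with a range from 0% to 8%.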

Compound 4, a percentage reported as inhibition, at one concentration (the size of the read-out at that concentration, not a potency): 0.1%
For compound 4 middle estimate and measured number coincide at the digits printed; low and high end bracket the measured number.
By their numbers in this assay, from the lowest: compounds 1, 2, 4 and 3 (each within the scatter of the next).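

In this assay, allyl in place of sec-butyl on the amine nitrogen gives a number 0 percentage points lower from compound 3 to compound 4 (within the scatter), and vinyl in place of ethyl on the saturated chain carbon bound to that nitrogen gives no change at the digits printed from compound 2 to compound 4 (within the scatter). The earlier step covered only an added methyl on this chain, whereas these two show that a double bond in the chain also leaves the read-out within the scatter, with compound 4 at 0.1%. No independent measurement bears on this result.

The compounds shown leave open whether a group of another kind on this nitrogen, such as a benzyl group, a chain ending in a carboxylic acid or a much longer alkyl chain, would lift the read-out beyond the scatter. They also leave open how these compounds would compare at other concentrations, since a single-concentration percentage is not a potency.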